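A few compounds are considered here, and "the series" means these few. Any claim that something is new, unique, unknown or untested is made for them only; others in the source may bear on it.

Going by the values given here, compound 1 `COc1ccc(F)cc1CNCCCNc1ccnc2cc(C3CCCCC3)ccc12` is one of three compounds measured in an ADME assay for permeability, using PAMPA, with a stated time of 30 min, at pH 7.4; on this read-out lower numbers stand for lower permeability and higher numbers for higher permeability. In this assay compound 1 gives 23 10^-6 cm/s, and compound 3 `c1coc(CNCCCNc2ccnc3cc(C4CCCCC4)ccc23)c1` gives 23 10^-6 cm/s; the step from compound 1 to compound 3 is no change at the digits printed from compound 1 to compound 3 (within the scatter), where the change is furan-2-yl in place of 5-fluoro-2-methoxyphenyl on a saturated chain carbon bound to an amine nitrogen. These two values together are the lowest of the three. Compound 2 `COc1cccc(CNCCCNc2ccnc3cc(-c4ccc(F)cc4)ccc23)c1O` differs from compound 1 in two places. In this assay compound 2 gives 237 10^-6 cm/s, a much higher number; with two changes at once, nothing can be attributed to either of them alone.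

Compound 4 `COc1ccc(F)cc1CNCCCNc1ccnc2cc(CC3CCCCC3)ccc12` has not yet been measured. It differs from compound 1 in one place: cyclohexylmethyl in place of cyclohexyl on an aromatic carbon. Among the compounds with values here, no measured step touches this part of the shared core, so no direct precedent exists; the one measured single-place step, elsewhere in the molecule, left the number unchanged. Compound 4 is therefore expected to sit close to compound 1, with the step of a 1.3-fold higher number from compound 1 to compound 4 (0.12 log units; within the scatter) not clearly beyond the scatter. The estimate for compound 4 in this assay is 30 10^-6 cm/s, with a likely range from 12 10^-6 cm/s to 75 10^-6 cm/s.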

Compound 4, apparent permeability: 23 10^-6 cm/s
Compound 4: the middle estimate sits 1.3-fold (0.12 log units) above what was measured, and the stated range covers the measured number.
By their numbers in this assay, from the lowest: compounds 1, 3 and 4 (each within the scatter of the next); then compound 2.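

In this assay, going by these compounds alone, the new result gives the first reading at this position of the shared core: no change at the digits printed from compound 1 to compound 4 (within the scatter), with cyclohexylmethyl in place of cyclohexyl on an aromatic carbon. The earlier single-place step concerned a different part of the molecule, on a saturated chain carbon bound to an amine nitrogen, so it said nothing directly about this aromatic carbon. This step adds a carbon to the group, taking it from 6 heavy atoms to 7, while keeping the six-membered carbon ring and leaving hydrogen-bond donors and acceptors at 0, and the read-out stays within the scatter, though no measurement available here accounts for that outcome.

Going by these compounds, it remains open whether a longer chain carrying the same ring, or an amine or a carboxylic acid on this aromatic carbon, would give a number beyond the scatter. Also open, on these data alone, is whether cyclohexylmethyl would give the same result alongside furan-2-yl, the group carried by compound 3, and compound 2 still cannot settle this position because it differs from compound 1 in two places.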